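This account rests on a few compounds, and the source may have more. Where it says the series, first, only, none or still open, it means among the compounds named here.

Among the measured compounds shown here, in a functional assay on T47D cells (Homo sapiens) for cytotoxicity, read by MTT assay (on this read-out higher numbers stand for weaker inhibition and lower numbers for stronger inhibition), compound 1 `O=C(/C=C/c1ccc(N2CCCC2)cc1)c1ccc(O)cc1` gives 1370 nM, the only exact number so far. Compound 2 `COc1ccc(/C=C/C(=O)c2ccc(F)cc2)cc1Br` gives > 25000 nM, which is a limit and not a number. For the measured compounds named here, compound 1 is therefore the single firm reference point, and no measured pair of compounds differing in one place shows how far such a change can move the read-out.

Compound 3 `O=C(/C=C/c1ccc(N2CCCC2)cc1)c1ccc(F)cc1` keeps the core of compound 1 and changes one group, with fluoro in place of hydroxy on an aromatic carbon, para to a large group: fluoro in place of hydroxy on an aromatic carbon. In other words, 4-hydroxyphenyl becomes 4-fluorophenyl.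

Going by the values given here, with no measured step to lean on, the expectation starts from compound 1 at 1370 nM. A moderate move towards weaker inhibition in this assay is expected, although a shift no larger than the usual scatter would be quite possible. The expected change is a 1.8-fold higher number from compound 1 to compound 3 (0.26 log units; within the scatter). For compound 3 the estimated value is 2500 nM, with an expected range from 600 nM to 12000 nM.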

Compound 3, half-maximal inhibitory concentration: > 25000 nM
Compound 3: no number, only a limit; the forecaster's own chance of this, stated with the estimate: 8%; middle value at least 10-fold (1.00 log units) away from the limit.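

Among the compounds shown here, this is the first measured step at this position. In this assay, replacing 4-hydroxyphenyl with 4-fluorophenyl on the shared core gives an at least 18-fold higher number from compound 1 to compound 3 (1.26 log units; beyond the scatter), so exchanging one heavy atom on an aromatic carbon, para to a large group, is enough to turn a firm number into no number at all. The true size of the step remains unknown, and the printed figure is only its smallest possible size, because the value for compound 3 is a limit and not a number: the limit of > 25000 nM in this assay, at which 2 of the 3 values shown sit.

The hydroxy group leaves with a hydrogen-bond donor and a hydrogen-bond acceptor, and the fluoro group enters with neither, but this single exchange cannot show which feature of the hydroxy group matters, and a methoxy or amino group at the same place would help to separate these possibilities. With only one such pair shown, it also remains open whether the same exchange would have a similar effect on a different core.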